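Propyl ester step read across two cores

A few compounds are considered here, and "the series" means these few. Any claim that something is new, unique, unknown or untested is made for them only; others in the source may bear on it.

Compound 1 `COC(=O)C1=C(C)NC(=O)NC1c1cccs1` gives 6% in an assay on membranes from CHO cells for displacement of a labelled ligand from adenosine receptor A1 (Homo sapiens), read by scintillation counting, with a stated time of 60 min, tested at 1 uM; on this read-out higher numbers stand for more inhibition at the one concentration tested (going by the name of the read-out) and lower numbers for less inhibition. Compound 2 `CCCOC(=O)C1=C(C)NC(=O)NC1c1cccs1` differs from it by ethyl in place of hydrogen on a saturated chain carbon bound to an oxygen next to a carbonyl group and gives 43% in this assay, a step of a number 37 percentage points higher from compound 1 to compound 2 (beyond the scatter). Compound 3 `COC(=O)C1=C(C)NC(=S)NC1c1ccoc1` carries a different core; the difference between the two cores is not broken down here. In this assay compound 3 gives 25%. Compound 4 `CCCOC(=O)C1=C(C)NC(=S)NC1c1ccoc1` differs from compound 3 by ethyl in place of hydrogen on a saturated chain carbon bound to an oxygen next to a carbonyl group, the same change at the same place as before. Going by these compounds, for compound 4 the expected step is a number 25 percentage points higher from compound 3 to compound 4 (beyond the scatter) in this assay, smaller than the earlier step because a number 37 percentage points higher from compound 1 to compound 2 (beyond the scatter) rests on a single pair and the second core is untested for this change. The estimate for compound 4 is 50%, expected between 30% and 75%.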

Compound 4, a percentage reported as inhibition, at one concentration (the size of the read-out at that concentration, not a potency): 4%
Compound 4: middle estimate off by 46 percentage points, on the high side, and the stated range ends above it.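

Read in this assay, the change from methoxycarbonyl to propoxycarbonyl gives a number 21 percentage points lower from compound 3 to compound 4 (beyond the scatter), so the rise seen on the core of compound 1 does not carry over to the core of compound 3. The two steps differ in direction and in size: the same change on two cores in this assay, a number 37 percentage points higher (beyond the scatter) from compound 1 to compound 2 and a number 21 percentage points lower (beyond the scatter) from compound 3 to compound 4, 58 percentage points apart, beyond the scatter of two such steps

In this series, a step measured on one core therefore cannot be transferred to the other, but each core rests on a single pair, and these pairs do not show which part of the difference between the cores goes with the reversal. Going by these compounds, whether a longer chain such as butoxycarbonyl, or a carboxylic acid in place of the ester, would follow the rise on the core of compound 1 or the fall on the core of compound 3 remains open.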